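Pyrazole urea series: carbonyl substituent change toward compound 4

The compounds below may be only part of what the source reports. "The series", "measured", "known", "first", "only" and "open" are said of these compounds alone.

Measured so far:
compound 1 `O=C(Nc1cccc(-n2cc(-c3ccncc3)c(-c3cc(O)cc(Cl)c3)n2)c1)Nc1ccc(Cl)c(C(F)(F)F)c1` — 13.4%
compound 2 `COc1cc(Cl)cc(-c2nn(-c3cccc(NC(=O)Nc4ccc(Cl)c(C(F)(F)F)c4)c3)cc2-c2ccncc2)c1` — 2.57%
compound 3 `COc1cc(Cl)cc(-c2nn(-c3cccc(NC(=O)Nc4cc(C(F)(F)F)cc(C(F)(F)F)c4)c3)cc2-c2ccncc2)c1` — 3.81%

In a functional assay on MCF7 cells (Homo sapiens) for inhibition, read by sulforhodamine B assay, with a stated time of 48 h, tested at 10 uM (a higher number here means a weaker effect of the compound at the concentration tested, a lower number a stronger effect), compound 2 gives 2.57%, the lowest of the three numbers shown. Compound 3 sits within the scatter of it, so no order between those two is claimed. Compound 1 lies further off; the step of a number 10.8 percentage points lower from compound 1 to compound 2 (beyond the scatter) is beyond the scatter.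

Compound 4 `COc1cc(Cl)cc(-c2nn(-c3cccc(NC(=O)c4cccc(C(F)(F)F)c4)c3)cc2-c2ccncc2)c1` is not yet measured. It differs from compound 2 in one place: 3-(trifluoromethyl)phenyl in place of (4-chloro-3-(trifluoromethyl)phenyl)amino on a carbonyl carbon.

Among the compounds with values here, none of the measured steps bears on this change. The step from compound 1 to compound 2 concerns the oxygen substituent only, and compounds 2 and 3 differ at a different part of the same end of the molecule, with values within the scatter of each other. The removal of a donor-bearing linking group on the carbonyl carbon is thus uncharted in this set, and the expectation can only be tentative, leaning toward a weaker effect.

For compound 4 the expected read-out is 22%, with a range from 3% to 60%. The step implied, a number 19.4 percentage points higher from compound 2 to compound 4 (beyond the scatter), is expected but not anchored by a measured analogue.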

Compound 4, a percentage reported as activity, at one concentration (the size of the read-out at that concentration, not a potency): 39.4%
The estimate for compound 4 lay 17.4 percentage points below the measured number; low and high end bracket the measured number.
By their numbers in this assay, from the lowest: compounds 2, 3 and 1 (each within the scatter of the next, the first and the last beyond it); then compound 4.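

In this assay, the substituent on the carbonyl carbon is the most responsive point examined so far: a number 36.8 percentage points higher from compound 2 to compound 4 (beyond the scatter), against the smaller a number 10.8 percentage points lower from compound 1 to compound 2 (beyond the scatter) at the oxygen substituent. Replacing (4-chloro-3-(trifluoromethyl)phenyl)amino with 3-(trifluoromethyl)phenyl on this carbonyl carbon therefore weakens the effect at the concentration tested, whereas compounds 2 and 3, which both keep an amino link to the outer aromatic ring, lie within the scatter of each other. No supporting data are available to explain this loss.

The change removes the amino nitrogen, with its hydrogen-bond donor, and the chlorine together, so the compounds shown cannot separate their contributions. Open questions are how 4-chloro-3-(trifluoromethyl)phenyl directly on the carbonyl carbon would read out, and whether a methylene link in place of the amino nitrogen would retain the effect.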